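The compounds below may be only part of what the source reports. "The series", "measured", "known", "first", "only" and "open" are said of these compounds alone.

Measured so far, in an assay on brain with Translocator protein (Rattus norvegicus) as the target; a lower number here means a stronger inhibitor, a higher number a weaker inhibitor:
compound 1, `CCOC(=O)c1c(CN(CC)Cc2ccccc2)nc2ccccc2c1-c1ccccc1`: 700 nM
compound 2, `CCN(Cc1ccccc1)Cc1nc2ccccc2c(-c2ccccc2)c1C(=O)N(CC)CC`: 373 nM
compound 3, `CCCNC(=O)c1c(CN(CC)Cc2ccccc2)nc2ccccc2c1-c1ccccc1`: 872 nM

Compound 3 gives the highest of the three numbers; its gap to compound 1 lies within the scatter, its gap to compound 2 beyond it. Compound 4, `CCN(Cc1ccccc1)Cc1nc2ccccc2c(-c2ccccc2)c1C(=O)N(C)C`, differs from compound 3 by dimethylamino in place of propylamino on a carbonyl carbon. The step that bears on this is a 2.3-fold higher number from compound 2 to compound 3 (0.37 log units; beyond the scatter), which runs the same way round, from a tertiary to a secondary amide; the steps of a 1.9-fold lower number from compound 1 to compound 2 (0.27 log units; within the scatter) and a 1.2-fold higher number from compound 1 to compound 3 (0.10 log units; within the scatter) frame it. Going back to a tertiary amide, a step of about a 1.9-fold lower number from compound 3 to compound 4 (0.29 log units; within the scatter) toward lower numbers is expected for compound 4. Compound 4 is thus estimated at 450 nM, in the range 200 nM to 1000 nM.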

Compound 4, half-maximal inhibitory concentration: 229 nM
The estimate for compound 4 lay 2.0-fold (0.29 log units) above the measured number; measured number inside the range.
By their numbers in this assay, from the lowest: compounds 4, 2, 1 and 3 (each within the scatter of the next, the first and the last beyond it).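

In this assay, the dimethylamino amide stands clear of the propylamino amide (a 3.8-fold lower number from compound 3 to compound 4 (0.58 log units; beyond the scatter)) and of the ethoxy ester (a 3.1-fold lower number from compound 1 to compound 4 (0.49 log units; beyond the scatter)), a separation from the ester that the diethylamino amide did not reach (a 1.9-fold lower number from compound 1 to compound 2 (0.27 log units; within the scatter)). The two tertiary amides cannot be ordered (a 1.6-fold lower number from compound 2 to compound 4 (0.21 log units; within the scatter)), so shortening diethylamino to dimethylamino shows no clear change. Nothing measured here accounts for these differences.

Compound 3 alone carries an amide hydrogen, so its effect cannot be separated from that of chain length. A methylamino or pyrrolidinyl group on the carbonyl carbon would help to separate them.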